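The compounds below may be only part of what the source reports. "The series", "measured", "known", "first", "only" and "open" are said of these compounds alone.

Among the measured compounds shown here, in a functional assay for antagonist activity at transient receptor potential cation channel subfamily V member 1 (Homo sapiens), read by FLIPR and calcium flux (a higher number here means a weaker inhibitor, a lower number a stronger inhibitor), compound 2 `O=C1COc2ccc(NC(=O)C3CCN(c4cccc(Cl)c4)CC3)cc2N1` gives 190 nM, the lowest of the two numbers known here. Compound 3 `O=C(Nc1cnc2ccccc2c1)C1CCN(c2cccc(C(F)(F)F)c2)CC1` gives 600 nM, and the gap between the two lies beyond the usual scatter of repeated measurements. For compound 1 `CC(=O)N1CCc2cc(NC(=O)C3CCN(c4cccc(C(F)(F)F)c4)CC3)ccc21` the assay returns only a limit, > 9000 nM, rather than a number. Compound 4 `Cc1c(Cl)cccc1N1CCC(C(=O)Nc2ccc3c(c2)NC(=O)CO3)CC1` has not yet been measured. It differs from compound 2 in one place: methyl in place of hydrogen on an aromatic carbon, a methyl in place of hydrogen on an aromatic carbon. For the measured compounds named here, no measured pair of compounds carries this same change, so its size can only be expected. The step expected here, a 1.3-fold lower number from compound 2 to compound 4 (0.10 log units; within the scatter), is modest and points toward a lower number. Compound 4 is therefore estimated at 150 nM, within a range from 50 nM to 500 nM.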

Compound 4, half-maximal inhibitory concentration: 100 nM
Compound 4: middle estimate off by 1.5-fold (0.18 log units), on the high side; measured number inside the range.
By their numbers in this assay, from the lowest: compounds 4 and 2 (each within the scatter of the next); then compound 3. At a limit, above all of these: compound 1.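

Read in this assay, the change from 3-chlorophenyl to 3-chloro-2-methylphenyl gives a 1.9-fold lower number from compound 2 to compound 4 (0.28 log units; within the scatter) and is the first step here between compounds that differ in one place. A methyl on this aromatic carbon, ortho to a chloro group, therefore leaves the number within the scatter of the parent compound. Nothing measured here bears on the reason for this result.

This single step shows no trend at the position. As far as these compounds go, whether an ethyl group, a methoxy group or an amine there would give a similar number remains open.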